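The compounds below may be only part of what the source reports. "The series", "measured", "known", "first", "only" and "open" are said of these compounds alone.

Values measured in a functional assay on MCF7 cells (Homo sapiens) for cytotoxicity, read by MTT assay, with a stated time of 72 h (a higher number here means a weaker inhibitor, a lower number a stronger inhibitor), are these:
- compound 1 `COc1ccc(/C=C2\CCC/C(=C\c3ccc(Cl)cc3)C2=O)cc1OC` gives 6300 nM
- compound 2 `COc1ccc(/C=C2\CCC/C(=C\c3ccc(Br)cc3)C2=O)cc1OC` gives 6900 nM
- compound 3 `COc1ccc(/C=C2\CCC/C(=C\c3cccc(Cl)c3Cl)C2=O)cc1OC` gives 14300 nM

Compound 3 has the highest number of the three and is the weakest of them. Compound 4 `COc1ccc(/C=C2\CCC/C(=C\c3ccc(Cl)c(Cl)c3)C2=O)cc1OC` has not yet been measured. It has 3,4-dichlorophenyl in place of 2,3-dichlorophenyl on a double-bonded chain carbon bound to a double-bonded ring carbon. Among the compounds with values here, no measured step makes this exact change, so the evidence is indirect. Bromo in place of chloro gave a 1.1-fold higher number from compound 1 to compound 2 (0.04 log units; within the scatter) and so compounds 1 and 2 can be read together. The modest steps to the 2,3-dichlorophenyl compound are a 2.3-fold higher number from compound 1 to compound 3 (0.36 log units; beyond the scatter) and a 2.1-fold higher number from compound 2 to compound 3 (0.32 log units; beyond the scatter) and they are the closest guide. On that basis, compound 4 is expected to move back by a similar modest amount towards a lower number in this assay as its group is no longer 2,3-dichlorophenyl. The estimated change is a 1.8-fold lower number from compound 3 to compound 4 (0.25 log units; within the scatter) and it remains an expectation. For compound 4 the estimated value is 8000 nM with an expected range from 4000 nM to 15000 nM in this estimate.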

Compound 4, half-maximal inhibitory concentration: 4400 nM
The estimate for compound 4 lay 1.8-fold (0.26 log units) above the measured number; the measured number falls inside the stated range.
By their numbers in this assay, from the lowest: compounds 4, 1 and 2 (each within the scatter of the next); then compound 3.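

In this assay, the two dichlorophenyl compounds have the same atoms joined differently, yet the change to 3,4-dichlorophenyl gives a 3.3-fold lower number from compound 3 to compound 4 (0.51 log units; beyond the scatter), so at this place the arrangement of the two chloro groups matters and not only their presence. Chloro in place of hydrogen gives a 1.4-fold lower number from compound 1 to compound 4 (0.16 log units; within the scatter) and 3,4-dichlorophenyl in place of 4-bromophenyl gives a 1.6-fold lower number from compound 2 to compound 4 (0.20 log units; within the scatter), so a second chloro group as such brings no readable change, and among these four only the 2,3-dichlorophenyl compound stands apart. Nothing in the data shown offers a reason for this difference.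

Going by these compounds, all four compounds carry only chloro or bromo on this ring, so how a nitrile, a trifluoromethyl or an amine would behave at this place remains open. On these data alone, whether the same order would hold with the other side of the shared core changed also remains open.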